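The compounds below may be only part of what the source reports. "The series", "measured", "known", "first", "only" and "open" are said of these compounds alone.

In a functional assay on A549 cells (Homo sapiens) for inhibition, read by sulforhodamine B assay, with a stated time of 72 h (on this read-out lower numbers stand for stronger inhibition and higher numbers for weaker inhibition), two compounds of a shared core have been measured. Compound 1 `CC1CCN(C(=O)c2c(N)sc(-c3ccc(Cl)cc3)c2-c2ccc(Cl)cc2)CC1` gives 1750 nM, while compound 2 `CN1CCN(C(=O)c2c(N)sc(-c3ccc(Cl)cc3)c2-c2ccc(Cl)cc2)CC1` gives 590 nM. Going by the values given here, the only measured step, a 3.0-fold lower number from compound 1 to compound 2 (0.47 log units; beyond the scatter), shows that changing the amide partner of the carbonyl carbon moves the read-out by a clear margin. Among the compounds with values here, on these two numbers compound 2 stands lowest, with compound 1 as its only neighbour.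

The next compound, compound 3 `Nc1sc(-c2ccc(Cl)cc2)c(-c2ccc(Cl)cc2)c1C(=O)NC1CC1`, differs from compound 2 at the same carbonyl carbon: cyclopropylamino in place of 4-methylpiperazin-1-yl on a carbonyl carbon. Within the data shown here, the step from compound 1 to compound 2 bears on this change only loosely, since it swapped one six-membered ring for another while the new group is a three-membered ring with a hydrogen-bond donor; no measured pair shows such a swap. Among the measured compounds shown here, the single step measured was modest, so compound 3 is expected to land near compound 2, with a step of a 1.4-fold higher number from compound 2 to compound 3 (0.13 log units; within the scatter) that may fall within the scatter or slightly above. Compound 3 is therefore estimated at 800 nM, within a range of 250 nM to 2500 nM.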

Compound 3, half-maximal inhibitory concentration: 1950 nM
Compound 3: the middle estimate sits 2.4-fold (0.39 log units) below what was measured; low and high end bracket the measured number.
By their numbers in this assay, from the lowest: compound 2; then compounds 1 and 3 (each within the scatter of the next).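

In this assay, the step of a 3.3-fold higher number from compound 2 to compound 3 (0.52 log units; beyond the scatter) shows that a small secondary amide on this carbonyl carbon does not hold the number reached with 4-methylpiperazin-1-yl, so this position responds to more than the exchange of one six-membered ring for another. Going by these compounds alone, the step of a 1.1-fold higher number from compound 1 to compound 3 (0.05 log units; within the scatter) adds that two quite different groups, cyclopropylamino and 4-methylpiperidin-1-yl, cannot be told apart here, which leaves 4-methylpiperazin-1-yl as the only one of the three groups whose number stands apart, beyond the scatter from both others. Nothing at hand goes beyond these numbers to account for that difference.

The change to cyclopropylamino alters the ring, the heavy atoms and the hydrogen-bond donors and acceptors all at once, so the compounds shown cannot say which of these differences matters. They also leave open whether a morpholin-4-yl group, a piperazin-1-yl group without the methyl, or an open-chain dimethylamino group on the same carbonyl carbon would stay with compound 2 or fall in with the other two.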